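Moving the chlorines on the benzyl ether of compound 2

The compounds below may be only part of what the source reports. "The series", "measured", "known", "first", "only" and "open" are said of these compounds alone.

In a functional assay on I10 cells (Mus musculus) for inhibition, read by MTT assay, with a stated time of 72 h (a higher number here means a weaker inhibitor, a lower number a stronger inhibitor), compound 2 `C=CCc1ccc(O)c(-c2ccc(OCc3c(Cl)cccc3Cl)c(CC=C)c2)c1` gives 16600 nM, the lowest of the two numbers in hand. Compound 1 `C=CCc1ccc(OCc2ccccc2)c(-c2ccc(O)c(CC=C)c2)c1` gives 21800 nM in this assay, a value within the scatter of that of compound 2, so the two cannot be placed in order. Compound 3 `C=CCc1ccc(OCc2ccc(Cl)c(Cl)c2)c(-c2ccc(OCc3ccc(Cl)c(Cl)c3)c(CC=C)c2)c1` returns no number in this assay but only a limit, > 50000 nM (the limit of > 50000 nM in this assay, at which 1 of the 3 values shown sits). Compound 4 `C=CCc1ccc(O)c(-c2ccc(OCc3ccc(Cl)cc3Cl)c(CC=C)c2)c1` has not been measured; it differs from compound 2 by 2,4-dichlorophenyl in place of 2,6-dichlorophenyl on a saturated chain carbon bound to an oxygen on an aromatic ring. Going by the values given here, no measured pair isolates this change, so the account rests on the two numbers alone. The author expects the step of a 1.1-fold higher number from compound 2 to compound 4 (0.04 log units; within the scatter) to stay within the scatter, in no clear direction. Compound 4 is therefore estimated at 18000 nM in this assay, with a range from 7000 nM to 45000 nM.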

Compound 4, half-maximal inhibitory concentration: 10400 nM
For compound 4 the middle estimate is 1.7-fold (0.24 log units) above the measured one; measured number inside the range.
By their numbers in this assay, from the lowest: compounds 4, 2 and 1 (each within the scatter of the next, the first and the last beyond it). At a limit, above all of these: compound 3.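

In this assay, 2,4-dichlorobenzyl in place of 2,6-dichlorobenzyl gives a 1.6-fold lower number from compound 2 to compound 4 (0.20 log units; within the scatter) and is the first change in one place among these compounds. At this position, therefore, the two chlorine patterns cannot be told apart, and the change of pattern alone gives no clear effect on the number. Nothing in hand bears on the cause of this step.

Still open, on these data alone, is whether an amine or a carboxylic acid in place of the chlorines, or a longer chain in place of the saturated chain carbon, would give a step beyond the scatter.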